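The source may report more compounds than this note shows. Statements on the series, on what has been measured and on what is new or still open speak of the compounds shown alone.

Measured compounds so far:
- compound 1: `N#Cc1ccc(C(=O)NC(=S)N2CCc3c(OCCCCCOc4ccc(Cl)cc4)cccc32)cc1`
- compound 2: `O=C(CCc1ccccc1)NC(=S)N1CCc2c(OCCCCCOc3ccc(Cl)cc3)cccc21`

In an ADME assay on Huh-7 cells (Homo sapiens) for cytotoxicity (on this read-out higher numbers stand for lower toxicity in this test and lower numbers for higher toxicity in this test), compound 1 gives only a limit of the assay, > 50000 nM. In this assay compound 2 likewise gives only a limit, > 50000 nM. Compound 2 therefore stands at the limit and cannot be placed more finely; every value shown sits at that same limit (the limit of > 50000 nM in this assay, at which 2 of the 2 values shown sit).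

The unmeasured compound 3 is `O=C(NC(=S)N1CCc2c(OCCCCCOc3ccc(Cl)cc3)cccc21)C1CCCCC1`. It differs from compound 2 by cyclohexyl in place of phenethyl on a carbonyl carbon. Within the data shown here, the one measured step that might bear on this change, a step that the two limits leave unreadable from compound 1 to compound 2, is left unreadable by its two limits, so no size can be carried over from it. No step beyond the scatter is expected in this assay for compound 3, and the step expected is a step that the limit leaves unreadable from compound 2 to compound 3. Compound 3 is estimated at 80000 nM, within 30000 nM to 300000 nM, and is expected most likely to be reported again only as a limit.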

Compound 3, half-maximal cytotoxic concentration: > 50000 nM
Compound 3: only a limit was reported (the forecaster's own chance of this, stated with the estimate: 85%); the middle value lies beyond the limit too.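

Compound 3 gives only a limit in this assay, as do compound 1 and compound 2, so no new step among these three can be read: the limit of > 50000 nM in this assay, at which 3 of the 3 values shown sit. The compounds shown leave open how far beyond that limit each lies, and whether cyclohexyl, phenethyl and 4-cyanophenyl on the carbonyl carbon differ at all.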